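This account rests on a few compounds, and the source may have more. Where it says the series, first, only, none or still open, it means among the compounds named here.

Measured so far:
compound 1 `CS(=O)(=O)c1ccc(Cc2nnc3n2N=C(c2ccc(-c4ccccc4)cc2)CS3)cc1` — 74.8%
compound 2 `CS(=O)(=O)c1ccc(Cc2nnc3n2N=C(c2ccc(O)c(C(N)=O)c2)CS3)cc1` — 37.1%

In a functional assay on RAW264.7 cells (Mus musculus) for cytotoxicity, read by MTT assay, with a stated time of 48 h, tested at 100 uM (a higher number here means a stronger effect of the compound at the concentration tested, a lower number a weaker effect), compound 1 gives 74.8%, while compound 2 gives 37.1%, the lower of the two numbers and beyond the scatter from compound 1. Compound 3 `CS(=O)(=O)c1ccc(Cc2nnc3n2N=C(c2ccccc2)CS3)cc1` differs from compound 2 by phenyl in place of 3-carbamoyl-4-hydroxyphenyl on a carbon with a double bond to nitrogen. Among the measured compounds shown here, no step between two measured compounds matches this change, so the expectation rests on the two values alone. Compound 3 is expected to sit between them, with the step of a number 17.9 percentage points higher from compound 2 to compound 3 (beyond the scatter) expected upward but uncertain in size. The estimate for compound 3 is 55%, ranging from 33% to 76%.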

Compound 3, a percentage reported as activity, at one concentration (the size of the read-out at that concentration, not a potency): 55.5%
Compound 3: middle estimate off by 0.5 percentage points, on the low side, and the stated range covers the measured number.
By their numbers in this assay, from the lowest: compound 2; then compound 3; then compound 1.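

With the bare phenyl as a reference point in this assay, the change at this carbon gives a number 18.4 percentage points higher from compound 2 to compound 3 (beyond the scatter), and replacing the outer phenyl with hydrogen on an aromatic carbon gives a number 19.3 percentage points lower from compound 1 to compound 3 (beyond the scatter). The two substitutions on this phenyl therefore move the number in opposite directions, with the 3-carbamoyl-4-hydroxyphenyl group below the phenyl reference and the biphenyl-type group above it. No available evidence explains either step. Whether the hydroxyl or the carbamoyl group alone accounts for the lower number remains open, as does the outcome with a methoxy group or an amine on this ring.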